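A few compounds are considered here, and "the series" means these few. Any claim that something is new, unique, unknown or untested is made for them only; others in the source may bear on it.

Measured so far:
compound 1 `Nc1ccc(S(=O)(=O)Nc2ccnc3cc(C(F)(F)F)ccc23)cc1` gives 46000 nM in a functional assay on HeLa cells (Homo sapiens) for antiproliferative activity, read by sulforhodamine B assay, with a stated time of 48 h; a higher number here means a weaker inhibitor, a lower number a stronger inhibitor;
compound 2 `N=C(N)NS(=O)(=O)c1ccc(N/C(S)=N\c2ccnc3cc(C(F)(F)F)ccc23)cc1` gives 23900 nM in this assay.

Of these two numbers compound 2 holds the lower one, yet the gap to compound 1 lies within the scatter, so the two cannot be ranked. Compound 3 `Cc1ccnc(NS(=O)(=O)c2ccc(N/C(S)=N\c3ccnc4cc(C(F)(F)F)ccc34)cc2)n1` has not been measured. It differs from compound 2 by a group of 7 heavy atoms (5 carbon, 2 nitrogen; one six-membered aromatic ring with 2 hetero atoms) in place of a group of 3 heavy atoms (1 carbon, 2 nitrogen; no ring), on a sulfonamide nitrogen. For the measured compounds named here, no measured pair shows the effect of such a change, so nothing beyond the scatter is expected; the estimated step of a 1.2-fold lower number from compound 2 to compound 3 (0.08 log units; within the scatter) is small. Compound 3 is expected to give about 20000 nM, in the range 7000 nM to 60000 nM.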

Compound 3, half-maximal inhibitory concentration: 31000 nM
Beside the measured number, compound 3's estimate is 1.6-fold (0.19 log units) below it, within the range that was stated.
By their numbers in this assay, from the lowest: compounds 2, 3 and 1 (each within the scatter of the next).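

On a sulfonamide nitrogen, the 4-methylpyrimidin-2-yl ring can take the place of the ring-free group of compound 2 and still leave this assay with a 1.3-fold higher number from compound 2 to compound 3 (0.11 log units; within the scatter) as the only readable result. The two compounds therefore cannot be ranked, and this larger ring-bearing group brings no change that can be told from the scatter. No measurement here bears on this result.

The compounds shown leave open whether a different group on this nitrogen, such as an acetyl group or a plain phenyl ring, would give a step beyond the scatter.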